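Replacing a Methyl With a Larger Group on Compound 1

The source may report more compounds than this note shows. Statements on the series, on what has been measured and on what is new or still open speak of the compounds shown alone.

Measured compounds and their values:
compound 1, `Cc1ccc(-c2ccc(C3(C)CC(S(=O)(=O)c4ccc(F)cc4)=C(c4ccc(/C(N)=N\O)cc4)O3)cc2)cc1`: 13700 nM
compound 2, `CCC1(c2ccccc2OC)CC(S(=O)(=O)c2ccc(F)cc2)=C(c2ccc(/C(N)=N\O)cc2)O1`: 27000 nM
compound 3, `N/C(=N/O)c1ccc(C2=C(S(=O)(=O)c3ccc(F)cc3)CC(c3ccccc3)(c3ccccc3)O2)cc1`: 19200 nM

Of the compounds shown here, three built on a shared core have been tested in an ADME assay on HepG2 cells (Homo sapiens) for cytotoxicity, read by MTT assay, with a stated time of 72 h; on this read-out higher numbers stand for lower toxicity in this test and lower numbers for higher toxicity in this test. Compound 1 gives the lowest of the three numbers, yet its gap to compound 3 and its gap to compound 2 both lie within the usual scatter of repeated measurements, so on these numbers the three compounds cannot be told apart. For the measured compounds named here, no two of the measured compounds differ in only one place, so there is no measured step that shows how a single change moves the result in this assay.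

Compound 4, `CC1(c2ccc(-c3ccc(/C(N)=N\O)cc3)cc2)CC(S(=O)(=O)c2ccc(F)cc2)=C(c2ccc(/C(N)=N\O)cc2)O1`, has not yet been measured. It differs from compound 1 in one place: a group of 4 heavy atoms (1 carbon, 2 nitrogen, 1 oxygen; no ring) in place of one carbon atom, on an aromatic carbon

Going by the values given here, with no measured step to build on, the expectation for compound 4 rests on the value of compound 1 alone, and the step of a 1.3-fold higher number from compound 1 to compound 4 (0.12 log units; within the scatter) is expected to be small, most likely staying within the scatter in either direction. Compound 4 is estimated at 18000 nM, with a range from 8000 nM to 40000 nM.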

Compound 4, half-maximal cytotoxic concentration: 15300 nM
Compound 4: middle estimate off by 1.2-fold (0.07 log units), on the high side; the range from low to high includes it.
By their numbers in this assay, from the lowest: compounds 1, 4, 3 and 2 (each within the scatter of the next).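

For the compounds shown here, the one-place step in this assay is a 1.1-fold higher number from compound 1 to compound 4 (0.05 log units; within the scatter), and it is the first measured step that shows what a single change does in this set. On an aromatic carbon of a six-membered aromatic ring of carbon only, para to a large group, methyl gives way to a group of 4 heavy atoms that brings 2 hydrogen-bond donors and 2 hydrogen-bond acceptors, yet compound 1 and compound 4 cannot be told apart in this test, so at this position a clearly larger group with these added donors and acceptors comes with no readable difference. Nothing measured here accounts for this result.

From the compounds shown here alone, whether an amine or a carboxylic acid on that same aromatic carbon would also give a number that cannot be told apart from compound 1 remains open. A single step at a single position also cannot show whether a longer chain or a chlorine atom there would behave the same way in this assay.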